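Swapping Trifluoromethyl for Bromo in a Phosphatase Series

The source may hold more compounds than are shown below. What is called first, only, known or untested is meant among the compounds shown, and "the series" means these compounds.

Compound 1, `O=C1NC(=S)S/C1=C\C=C\c1ccccc1OCc1ccccc1C(F)(F)F`, gives 40.8%
Compound 2, `O=C1NC(=S)S/C1=C\C=C\c1ccccc1OS(=O)(=O)c1ccccc1`, gives 64.2%
Compound 3, `O=C1NC(=S)S/C1=C\C=C\c1ccccc1Cl`, gives 53.9%

Of the compounds shown here, three sharing one core have been measured in an assay on isolated protein for inhibition of protein tyrosine phosphatase type IVA 3 (Homo sapiens), tested at 5 ug/mL; a higher number here means more inhibition at the concentration tested (going by the name of the read-out), a lower number less inhibition. Among them compound 1 stands lowest. Its nearest neighbour is compound 3, whose number lies higher by a margin beyond the usual scatter, and compound 2 lies higher still, also beyond the scatter. Compound 4, `O=C1NC(=S)S/C1=C\C=C\c1ccccc1OCc1ccccc1Br`, has not yet been measured. It differs from compound 1 in a single place: bromo in place of trifluoromethyl on an aromatic carbon. For the measured compounds named here, no two of the measured compounds differ from each other in only one place, so there is no measured step that bears directly on this change; the trio only shows that the group attached through the ether oxygen, or a chloro in its stead, moves the read-out across a range of a few tens of points. Without a guiding step, the step from compound 1 to compound 4 is expected to be small, a number 4.2 percentage points higher from compound 1 to compound 4 (within the scatter), most likely within the scatter and with no firm direction. Compound 4 is therefore expected to give about 45%, within a range from 30% to 62%.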

Compound 4, a percentage reported as inhibition, at one concentration (the size of the read-out at that concentration, not a potency): 63.1%
Compound 4: middle estimate off by 18.1 percentage points, on the low side; measured number outside the range, above it.
By their numbers in this assay, from the lowest: compound 1; then compounds 3, 4 and 2 (each within the scatter of the next, the first and the last beyond it).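

For the compounds shown here, the exchange of trifluoromethyl for bromo on an aromatic carbon, ortho to a large group, is the first change in this assay that can be read at a single place, and it amounts to a number 22.3 percentage points higher from compound 1 to compound 4 (beyond the scatter) in the read-out. The earlier compounds shown here differed from one another in more than one place, so they could not show that this position on its own matters; here, with the rest of the structure held constant, a single replacement moves the read-out by a margin beyond the usual scatter. No measurement in hand bears on why this exchange has that effect.

As far as these compounds go, it remains open whether the step is particular to bromo or would also appear with other groups at this place, such as chloro, methoxy, a nitrile or plain hydrogen. From the compounds shown here alone, it is also open whether the same exchange would have a similar effect on the compounds with a different group on the ether oxygen, and how the step would translate into potency, as the read-out comes from one concentration.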